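The compounds below may be only part of what the source reports. "The series", "measured", "known", "first", "only" and "open" are said of these compounds alone.

Working notes on the series in an assay on cells for inhibition of Rho-associated protein kinase 2 (Homo sapiens), read by radiometric assay and 33P incorporation, in the presence of a further agent that is not named here; on this read-out higher numbers stand for weaker inhibition and lower numbers for stronger inhibition.

Compound 1 `CCCOC(=O)c1cccc(C(=O)Nc2cccc(-c3cc(C(=O)Nc4ccncc4F)ccc3CN)c2)c1` gives 1.8 nM in this assay. Compound 2 `NCc1ccc(C(=O)Nc2ccncc2F)cc1-c1cccc(NC(=O)c2cc(C(=O)O)ccc2F)c1` reaches only a limit of the assay in this assay, < 1 nM. Among the compounds with values here, that limit, (the limit of < 1 nM in this assay, at which 1 of the 3 values shown sits), is the one floor among the values shown. The step of an at least 1.8-fold lower number from compound 1 to compound 2 (0.25 log units; that floor lies within the scatter) is therefore a floored value and its size cannot be placed beyond the scatter. Compound 3 `NCc1ccc(C(=O)Nc2ccncc2F)cc1-c1cccc(C(=O)Nc2ccc(CC(=O)O)cc2)c1` gives 1.8 nM in this assay, level with compound 1 at the digits shown.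

Compound 4 `NCc1ccc(C(=O)Nc2ccncc2F)cc1-c1cccc(C(=O)Nc2cccc(C(=O)O)c2F)c1` is not yet measured. It differs from compound 3 by 3-carboxy-2-fluorophenyl in place of 4-(carboxymethyl)phenyl on an amide-type nitrogen. Within the data shown here, no measured step changes this amide-type nitrogen substituent; the only measured step, an at least 1.8-fold lower number from compound 1 to compound 2 (0.25 log units; that floor lies within the scatter), sits on the carbonyl side of the other amide and is bounded by the limit of compound 2, so it bears on the present change only loosely. The expectation for compound 4 is thus a step of about a 1.2-fold lower number from compound 3 to compound 4 (0.08 log units; within the scatter), within the scatter of compound 3. Compound 4 is estimated at 1.5 nM in this assay, between 0.5 nM and 4.5 nM.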

Compound 4, half-maximal inhibitory concentration: 3.5 nM
Compound 4: the middle estimate sits 2.3-fold (0.37 log units) below what was measured, and the stated range covers the measured number.
By their numbers in this assay, from the lowest: compounds 1, 3 and 4 (each within the scatter of the next). At a limit, below all of these: compound 2.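

Within the data shown here, on this amide-type nitrogen, 3-carboxy-2-fluorophenyl in place of 4-(carboxymethyl)phenyl gives a 1.9-fold higher number from compound 3 to compound 4 (0.29 log units; within the scatter), the first reading of any change at this place. In this assay, among these compounds, the two groups, which share the same count of heavy atoms, therefore cannot be told apart, and the single step assigns no share to the loss of the carboxymethyl chain, the new place of the carboxylic acid or the entering fluorine. Nothing measured here gives a cause for this step.

Going by these compounds, both groups at this place carry a carboxylic acid, so it remains open how the series reads with an amine, a primary amide or a longer chain ending in the acid on this nitrogen. On these data alone, compound 2 remains at a limit of the assay, < 1 nM, so its true value also stays open.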